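The source may report more compounds than this note shows. Statements on the series, on what has been measured and on what is new or still open speak of the compounds shown alone.

Measured compounds in this series:
- compound 1, `CCOC(=O)C1=C(C(F)(F)F)NC(=O)NC1c1ccsc1`, 32%
- compound 2, `CCOC(=O)C1=C(C(F)(F)F)NC(=O)NC1c1ccoc1`, 37%
- compound 3, `CC(C)OC(=O)C1=C(C(F)(F)F)NC(=O)NC1c1cccs1`, 8%

All three share a core and differ in the ester and in the aromatic ring on the saturated ring carbon. In an assay on cells for displacement of a labelled ligand from adenosine receptor A1 (Homo sapiens), read by radioligand binding, with a stated time of 60 min, tested at 1 uM (a lower number here means less inhibition, a higher number more inhibition at the concentration tested (going by the name of the read-out)), compound 3 gives the lowest of the three numbers; compound 1 stands nearest to it and compound 2 furthest, and both gaps lie beyond the scatter. Among the compounds with values here, the one measured single-point step, a number 5 percentage points higher from compound 1 to compound 2 (within the scatter), concerns the aromatic ring only and does not touch the ester.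

Compound 4, `CCOC(=O)C1=C(C(F)(F)F)NC(=O)NC1c1cccs1`, is not yet measured. It differs from compound 3 as follows: hydrogen in place of methyl on a saturated chain carbon bound to an oxygen next to a carbonyl group and a saturated chain carbon. Compound 4 thus carries the same ester as compound 1 and compound 2, whose numbers sit well above that of compound 3, while keeping the aromatic ring of compound 3. Within the data shown here, no measured pair differs in the ester alone, so the size of this step has no direct precedent. Given that compound 1 with the smaller ester gives 32% and compound 2 gives 37%, a rise from compound 3 to compound 4 of a number 14 percentage points higher from compound 3 to compound 4 (beyond the scatter) is expected in this assay, but with wide uncertainty. Compound 4 is estimated at 22%, with a range of 5% to 40%.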

Compound 4, a percentage reported as inhibition, at one concentration (the size of the read-out at that concentration, not a potency): 28%
For compound 4 the middle estimate is 6 percentage points below the measured one, and the stated range covers the measured number.
By their numbers in this assay, from the lowest: compound 3; then compounds 4, 1 and 2 (each within the scatter of the next).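

In this assay, within the data shown here, the change from isopropoxycarbonyl to ethoxycarbonyl gives a number 20 percentage points higher from compound 3 to compound 4 (beyond the scatter) with the thiophen-2-yl ring held constant, so this is the first direct reading of the ester on its own, and the single methyl at this position is enough to move the number beyond the scatter. The ring now looks far less decisive than the ester in this small set: with ethoxycarbonyl kept, the ring change gives a number 4 percentage points lower from compound 1 to compound 4 (within the scatter) and, likewise, a number 9 percentage points lower from compound 2 to compound 4 (within the scatter), so thiophen-2-yl, thiophen-3-yl and furan-3-yl cannot be told apart here. Nothing available bears on why the ester step has this size.

On these data alone, the ester position rests on one pair, so it remains open whether isopropoxycarbonyl lowers the number in the same way with a thiophen-3-yl or furan-3-yl ring. Also open, as far as these compounds go, is how the series responds to a methyl ester, a longer chain such as n-butyl, or a free carboxylic acid at this position, and to a phenyl ring on the saturated ring carbon.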